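Methyl for chloro in the benzylamine series

A few compounds are considered here, and "the series" means these few. Any claim that something is new, unique, unknown or untested is made for them only; others in the source may bear on it.

Compound 3 `O=c1cc(CNCc2ccc(Cl)cc2)oc2ccc(O)c(O)c12` in an ADME assay on Huh-7 cells (Homo sapiens) for cytotoxicity (on this read-out lower numbers stand for higher toxicity in this test and higher numbers for lower toxicity in this test), gives only a limit, > 100000 nM. Compound 1 `O=c1cc(CNCc2ccccc2Cl)oc2ccc(O)c(O)c12` likewise sits at a limit, > 100000 nM. Two of the three values reported share that limit (the limit of > 100000 nM in this assay, at which 2 of the 3 values shown sit). Compound 2 `Cc1ccccc1CNCc1cc(=O)c2c(O)c(O)ccc2o1` gives 52200 nM in this assay. Compound 4 `Cc1ccc(CNCc2cc(=O)c3c(O)c(O)ccc3o2)cc1` carries methyl in place of chloro on an aromatic carbon. The same exchange seen once before, an at least 1.9-fold lower number from compound 1 to compound 2 (0.28 log units; that floor lies within the scatter), rests on a floor that lies within the scatter. The steps a step that the two limits leave unreadable from compound 1 to compound 3 and an at least 1.9-fold higher number from compound 2 to compound 3 (0.28 log units; that floor lies within the scatter) change the ring substituent pattern instead and bear on this change only indirectly. A lowering in this assay, if any, is therefore expected to stay within the scatter. Compound 4 is expected near 70000 nM, between 30000 nM and 150000 nM. That estimate amounts to an expected step of an at least 1.4-fold lower number from compound 3 to compound 4 (0.15 log units; that floor lies within the scatter).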

Compound 4, half-maximal cytotoxic concentration: > 100000 nM
Compound 4: only a limit was reported (the forecaster's own chance of this, stated with the estimate: 50%); at least 1.4-fold (0.15 log units) between middle value and limit.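

With methyl in place of chloro at this position, compound 4 joins compounds 1 and 3 at the limit in this assay, so the change gives no readable size here. Going by these compounds alone, the steps to compound 4 from compound 3 and from compound 1 cannot be read, as each joins two limits: the limit of > 100000 nM in this assay, at which 3 of the 4 values shown sit. The only readable step bears on where the methyl sits, an at least 1.9-fold higher number from compound 2 to compound 4 (0.28 log units; that floor lies within the scatter), and its floor stays within the scatter.

Going by these compounds, whether chloro and methyl truly differ at this position remains open while both rest on a limit. Also open, on these data alone, is whether a methoxy group or an amine there would give a measurable value in this assay.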